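Turning One Stereocentre in Compound 1

The source may hold more compounds than are shown below. What is called first, only, known or untested is meant among the compounds shown, and "the series" means these compounds.

Compound 1 (`CC(=O)O[C@@]1(C)CCC(=O)[C@H](C)CCC[C@]2(C)O[C@H]2C(=O)C(=C(C)C)CC1`) : 38900 nM
Compound 2 (`CC(C)=C1CC[C@]2(C)CC[C@]3(O[C@H](C[C@H]3C)C[C@]3(C)O[C@H]3C1=O)O2`) : 48100 nM

Both numbers come from a functional assay on NCI-H292 cells (Homo sapiens) for cytotoxicity, read by MTT assay, with a stated time of 24 h (a higher number here means a weaker inhibitor, a lower number a stronger inhibitor), a test of how much of a compound it takes to harm cultured cells. Compound 1 has the lowest of the two numbers, but only just: compound 2 lies within the usual scatter of repeated measurements, so the pair cannot be told apart. The next compound to be tested is compound 3 (`CC(=O)O[C@@]1(C)CCC(=O)[C@@H](C)CCC[C@]2(C)O[C@H]2C(=O)C(=C(C)C)CC1`). Its difference from compound 1 is subtle: the two compounds have the same atoms and bonds and differ only in configuration as drawn: 1 of 4 stereo elements differ; a stereocentre at a saturated ring carbon is drawn R in compound 1 and S in compound 3. No atom or bond is added or lost, so the two are mirror-different at that one carbon only, while the other stereo elements stay as drawn.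

Among the compounds with values here, no measured pair here shows what such an inversion does, so there is no direct precedent. With nothing pointing either way, no change beyond the scatter is expected, and the reasoning rests on compound 1 at 38900 nM as the starting point. The expected size of the change is a 1.0-fold higher number from compound 1 to compound 3 (0.01 log units; within the scatter) in this estimate. The estimated value for compound 3 is 40000 nM, with an expected range from 20000 nM to 80000 nM as the measurement approaches.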

Compound 3, half-maximal inhibitory concentration: 21400 nM
Compound 3: middle estimate off by 1.9-fold (0.27 log units), on the high side; the range from low to high includes it.
By their numbers in this assay, from the lowest: compounds 3, 1 and 2 (each within the scatter of the next, the first and the last beyond it).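

Turning the saturated ring carbon from R to S, with the other stereo elements left as drawn, gives in this assay a 1.8-fold lower number from compound 1 to compound 3 (0.26 log units; within the scatter). Within the data shown here, this is the first comparison here between compounds that differ in one place, and it shows that the configuration at this carbon does not separate the pair by more than repeated measurements of the same compound would. The comparison is also a clean one, with no added or lost group to complicate its reading: the fact that compounds 1 and 3 differ only in the configuration as drawn

The compounds shown leave open whether inverting any of the other stereo elements would have a larger effect than this single inversion, since this step speaks for one carbon only. They also leave open whether an amine or a carboxylic acid in place of the acetate ester on the shared core would move the number beyond the scatter, and whether the R or S drawing at this carbon would begin to matter with such a group present.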